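The source may hold more compounds than are shown below. What is called first, only, known or untested is meant among the compounds shown, and "the series" means these compounds.

In a functional assay on HCT-116 cells (Homo sapiens) for antiproliferative activity, read by MTT assay, with a stated time of 24 h (on this read-out higher numbers stand for weaker inhibition and lower numbers for stronger inhibition), the three measured compounds stand as follows:

compound 1 `O=C1O/C(=C\Cn2cc(-c3ccccc3)nn2)C(OCc2ccccc2)=C1OCc1ccccc1`: > 100000 nM, a limit of the assay;
compound 2 `COC1=C(OC)C(O)(CCn2cc(-c3ccc(C(C)(C)C)cc3)nn2)NC1=O`: 50300 nM;
compound 3 `COC1=C(OC)C(O)(CCn2cc(-c3ccccc3)nn2)NC1=O`: 46300 nM.

For the measured compounds named here, compound 1 is the one compound for which this assay reports a limit rather than a number; (the limit of > 100000 nM in this assay, at which 1 of the 3 values shown sits). Compound 2 and compound 3 are built on a different core from compound 1, and the step between them is a 1.1-fold lower number from compound 2 to compound 3 (0.04 log units; within the scatter), which is too small to read as a change.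

The unmeasured compound 4 `O=C1O/C(=C\Cn2cc(-c3ccccn3)nn2)C(OCc2ccccc2)=C1OCc1ccccc1` keeps the core of compound 1 and differs from it in one place: pyridin-2-yl in place of phenyl on an aromatic carbon. Going by the values given here, no measured step on this core matches that change, and the only measured step, that from compound 2 to compound 3, concerns another group on another core, so it gives no guide to the size or direction of the move from phenyl to pyridin-2-yl. The expectation for compound 4 is therefore no step beyond the scatter, which a step that the limit leaves unreadable from compound 1 to compound 4 expresses. Compound 4 is expected at about 150000 nM, with a range from 50000 nM to 500000 nM, and will most likely again be reported as a limit.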

Compound 4, half-maximal inhibitory concentration: > 100000 nM
Compound 4: only a limit was reported (the forecaster's own chance of this, stated with the estimate: 70%); the middle value does not contradict the limit.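

In this assay, for the compounds shown here, compound 1 and compound 4 are each reported only as a limit, so no step between them can be read: the limit of > 100000 nM in this assay, at which 2 of the 4 values shown sit. The compounds shown leave open whether pyridin-2-yl in place of phenyl on the shared core changes antiproliferative activity at all, and if it does, in which direction and by how much.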